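A few compounds are considered here, and "the series" means these few. Any claim that something is new, unique, unknown or untested is made for them only; others in the source may bear on it.

Measured compounds:
- Compound 1 `COc1ccccc1-c1cccc(S(=O)(=O)N2CCC(N3CCC(C)CC3)CC2)c1`, which in an ADME assay on HCT-116 cells (Homo sapiens) for cytotoxicity, read by CellTiter-Glo, with a stated time of 72 h (on this read-out higher numbers stand for weaker inhibition and lower numbers for stronger inhibition), gives only a limit, > 5000 nM.
- Compound 2 `CC1CCN(C2CCN(S(=O)(=O)c3cn(C)cn3)CC2)CC1`, which in this assay gives only a limit, > 10000 nM.
- Compound 3 `CCc1ccc(S(=O)(=O)N2CCC(N3CCC(C)CC3)CC2)cc1`, which in this assay gives only a limit, > 5000 nM.

All three measured values are limits of the assay, not numbers. Compound 1 sits at the limit shared by two of the three values (the limit of > 5000 nM in this assay, at which 2 of the 3 values shown sit), while the remaining value sits at a different limit (the limit of > 10000 nM in this assay, at which 1 of the 3 values shown sits). Nothing here ranks compound 1 against compound 2 or compound 3.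

The unmeasured compound 4 `Cc1cc(C)cc(-c2cccc(S(=O)(=O)N3CCC(N4CCC(C)CC4)CC3)c2)c1` differs from compound 1 in one place: 3,5-dimethylphenyl in place of 2-methoxyphenyl on an aromatic carbon. Within the data shown here, the only measured step, a step that the two limits leave unreadable from compound 2 to compound 3, changes the group on the sulfonyl sulfur rather than the aryl group, and its size cannot be read. No measured step therefore gives a size or direction for the change to compound 4, and no movement beyond the scatter can be expected from the shown data.

Compound 4 is therefore expected to return another limit, with an estimate of 8000 nM and a range from 3000 nM to 30000 nM. The step that the limit leaves unreadable from compound 1 to compound 4 that this estimate means is expected to be no more than a move within or across the limit.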

Compound 4, half-maximal inhibitory concentration: > 5000 nM
Compound 4: no number, only a limit; the forecaster's own chance of this, stated with the estimate: 85%; the middle value is on the limit's open side.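

Compound 1 and compound 4 each give only a limit, not a number, so no step between them can be read: the limit of > 5000 nM in this assay, at which 3 of the 4 values shown sit.

The compounds shown leave open whether 3,5-dimethylphenyl in place of 2-methoxyphenyl changes the effect on these cells at all, with no compound here giving an actual number.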